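The source may hold more compounds than are shown below. What is called first, only, known or untested is meant among the compounds shown, and "the series" means these compounds.

Measured so far in a functional assay on the whole organism for antagonist activity, with Mus musculus as the target, in the maximal electroshock model; a lower number here means that less compound is needed, a higher number that more compound is needed for the effect:
Compound 1 `COc1ccc(-c2nnc(S(C)(=O)=O)n2C)cc1`: > 200 mg/kg (a limit)
Compound 2 `CSc1nnc(-c2ccccc2Cl)n1C`: > 50 mg/kg (a limit)
Compound 3 `CSc1nnc(-c2ccccc2F)n1C`: > 200 mg/kg (a limit)

None of the three entries is a true number, so no half-maximal dose has yet been read for this small set. Compound 3 gives > 200 mg/kg, which is a limit. It sits at the limit of > 200 mg/kg in this assay, at which 2 of the 3 values shown sit.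

Compound 4 `CCS(=O)(=O)c1nnc(-c2ccccc2F)n1C` carries ethylsulfonyl in place of methylsulfanyl on an aromatic carbon, between two ring nitrogen atoms: ethylsulfonyl in place of methylsulfanyl on an aromatic carbon.

Going by the values given here, only one measured step exists to compare with this change. That step, a step that the two limits leave unreadable from compound 2 to compound 3, is fluoro in place of chloro on an aromatic carbon, and it offers no size to carry over. Compound 1 also carries a sulfonyl group, on a core with a different aryl group, and it gives > 200 mg/kg, again a limit.

With no readable step behind the change, no shift beyond the usual scatter is expected in this assay, and no direction can be argued from the data. The expected change is an at least 1.3-fold lower number from compound 3 to compound 4 (0.12 log units; that floor lies within the scatter). For compound 4 the estimate is 150 mg/kg, with an expected range from 40 mg/kg to 400 mg/kg.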

Compound 4, dose for half-maximal effect: > 200 mg/kg
Compound 4: a limit, no number; the forecaster's own chance of this, stated with the estimate: 60%; middle value at least 1.3-fold (0.12 log units) from the limit.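

Compound 3 and compound 4 each give a limit and not a number in this assay, so no step can be read between them: the limit of > 200 mg/kg in this assay, at which 3 of the 4 values shown sit.

The compounds shown leave open how large the half-maximal dose of any of them is, and whether ethylsulfonyl in place of methylsulfanyl moves that dose at all.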